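Chloro to cyano step beside a fluoro substitution

The source may hold more compounds than are shown below. What is called first, only, known or untested is meant among the compounds shown, and "the series" means these compounds.

Measured compounds:
Compound 1 `O=C1Nc2ccccc2/C1=C/c1ccc(-c2cn(-c3cccc(Cl)c3)nn2)cc1`. In a functional assay on HT-29 cells (Homo sapiens) for inhibition, read by CCK-8 assay, with a stated time of 24 h (on this read-out higher numbers stand for weaker inhibition and lower numbers for stronger inhibition), compound 1 reaches only the limit > 20000 nM.
Compound 2 `N#Cc1cccc(-n2cc(-c3ccc(/C=C4\C(=O)Nc5ccccc54)cc3)nn2)c1`. In this assay compound 2 likewise reaches only the limit > 20000 nM.
Compound 3 `O=C1Nc2ccc(F)cc2/C1=C/c1ccc(-c2cn(-c3cccc(Cl)c3)nn2)cc1`. In this assay, for the measured compounds named here, compound 3 gives 10500 nM, the one number in the set.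

The change from compound 1 to compound 2 is cyano in place of chloro on an aromatic carbon. Its step, a step that the two limits leave unreadable from compound 1 to compound 2, cannot be sized because the limit of > 20000 nM in this assay, at which 2 of the 3 values shown sit, holds both ends. The cores of compound 1 and compound 3 differ by fluoro in place of hydrogen on an aromatic carbon, with the step of an at least 1.9-fold lower number from compound 1 to compound 3 (0.27 log units; that floor lies within the scatter).

Compound 4 `N#Cc1cccc(-n2cc(-c3ccc(/C=C4\C(=O)Nc5ccc(F)cc54)cc3)nn2)c1` is not yet measured. It differs from compound 3 by cyano in place of chloro on an aromatic carbon, the same change as from compound 1 to compound 2. The earlier step gives no usable size, so the expectation rests on compound 3 alone, at 10500 nM. The step from compound 3 to compound 4 is expected to be small, a 1.1-fold higher number from compound 3 to compound 4 (0.06 log units; within the scatter), with a real chance of a limit. Compound 4 is estimated at 12000 nM, between 4000 nM and 40000 nM.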

Compound 4, half-maximal inhibitory concentration: > 20000 nM
Compound 4 was reported as a limit; the forecaster's own chance of this, stated with the estimate: 45%; middle value at least 1.6-fold (0.22 log units) from the limit.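

In this assay, for the compounds shown here, the change from 3-chlorophenyl to 3-cyanophenyl reads as an at least 1.9-fold higher number from compound 3 to compound 4 (0.27 log units; that floor lies within the scatter), so its one readable instance gives a floor and not a size. Compound 4 gives > 20000 nM, which is a limit of the assay and not a number. The steps from compound 1 to compound 2 and from compound 2 to compound 4 cannot be read, so no size can be carried from one core to the other, and the data neither confirm nor exclude that the change acts alike on both cores: the limit of > 20000 nM in this assay, at which 3 of the 4 values shown sit.

Going by these compounds alone, open is how an amine or a carboxylic acid in place of chloro would read against compound 3 at 10500 nM, the one number in the set. Also open, on these data alone, is whether a methoxy group in place of fluoro on the shared core would give a readable number with either 3-chlorophenyl or 3-cyanophenyl.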